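The source may report more compounds than this note shows. Statements on the series, on what has been measured and on what is new or still open speak of the compounds shown alone.

Measured so far:
compound 1 `O=C(c1ccccc1)N1CCC(C(=O)N2N=CCC2c2ccccc2)CC1` — 4.4
compound 2 `O=C(C1CCN(c2cccnn2)CC1)N1N=CC[C@H]1c1ccccc1` — 3.4
compound 3 `Cc1nnc(N2CCC(C(=O)N3N=CC[C@H]3c3ccccc3)CC2)o1` — 3.2

In a physicochemical assay for lipophilicity, read by HPLC, measured as chromatographic lipophilicity, at pH 7.4 (on this read-out higher numbers stand for higher lipophilicity and lower numbers for lower lipophilicity), compound 1 stands highest of the three; compound 2 sits beyond the scatter below it, and compound 3 further still. Among the compounds with values here, the only one-place step measured, a number 0.20 log units lower from compound 2 to compound 3 (within the scatter), is within the scatter and concerns a different exchange at the same amine nitrogen, so it does not bear directly on the change at hand.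

Compound 4 `O=C(C1CCN(c2ccccc2)CC1)N1N=CCC1c1ccccc1` differs from compound 1 thus: phenyl in place of benzoyl on an amine nitrogen in a ring. Within the data shown here, no measured pair sets benzoyl against phenyl; compounds 2 and 3 carry pyridazin-3-yl and 5-methyl-1,3,4-oxadiazol-2-yl there, not phenyl, and both fall below compound 1. The leaving group counts one hydrogen-bond acceptor, the entering group none, so a modest upward step, a number 0.50 log units higher from compound 1 to compound 4 (beyond the scatter), is expected. Compound 4 is estimated at 4.9, range 4.3 to 5.5.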

Compound 4, distribution coefficient: 6.3
Beside the measured number, compound 4's estimate is 1.40 log units below it; measured number outside the range, above it.
By their numbers in this assay, from the lowest: compounds 3 and 2 (each within the scatter of the next); then compound 1; then compound 4.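

On an amine nitrogen in a ring, phenyl in place of benzoyl is a large change in this assay, with a number 1.90 log units higher from compound 1 to compound 4 (beyond the scatter). Within the data shown here, this is the first step at this position that lies beyond the scatter, so the group on this nitrogen can shift the read-out strongly. Nothing at hand accounts for the size of this step.

Open, on these data alone, is whether benzyl or cyclohexyl on the same nitrogen would stand nearer compound 1 or compound 4. Also open, as far as these compounds go, is how a phenyl carrying an amine or a carboxylic acid would read.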